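A few compounds are considered here, and "the series" means these few. Any claim that something is new, unique, unknown or untested is made for them only; others in the source may bear on it.

Compound 1 `N#CC1CN1C(=O)Nc1ccc(F)cc1` in a functional assay on MCF7 cells (Homo sapiens) for inhibition (a higher number here means a weaker inhibitor, a lower number a stronger inhibitor), gives 1900 nM.
Compound 2 `CC(C)(C)NC(=O)N1CC1C#N` in this assay gives > 300000 nM, which is a limit of the assay and not a number.

So compound 2 stands at the edge of what this assay reports, and one of the two values shown sits there (the limit of > 300000 nM in this assay, at which 1 of the 2 values shown sits). Compound 3 `CCNC(=O)N1CC1C#N` differs from compound 2 by a single change: ethyl in place of tert-butyl on an amide-type nitrogen. For the measured compounds named here, no step between measured compounds is available to gauge this change, so the expected step is small or none beyond the scatter, a number no higher from compound 2 to compound 3 (the limit leaves the size open). Compound 3 is therefore estimated at 300000 nM, within a range from 50000 nM to 1000000 nM, and will most likely again be reported only as a limit in this assay.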

Compound 3, half-maximal inhibitory concentration: 29000 nM
Estimate against measurement, compound 3: 10-fold (1.01 log units) above; measured number outside the range, below it.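

In this assay, ethyl in place of tert-butyl on the amide-type nitrogen gives an at least 10-fold lower number from compound 2 to compound 3 (1.01 log units; beyond the scatter), so an alkyl group at this position can give a measurable inhibitor, and the choice of alkyl group matters. Compound 3, at 29000 nM, still has a higher number than compound 1, at 1900 nM. The step's full size stays unknown, with compound 2 at the edge of what this assay reports: the limit of > 300000 nM in this assay, at which 1 of the 3 values shown sits.

From the compounds shown here alone, whether a methyl group or a longer chain such as n-butyl would lower the number further remains open, and so does how a benzyl group would compare.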